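Removal of the ring nitrogen phenyl in a pyrazoline amide series

This account rests on a few compounds, and the source may have more. Where it says the series, first, only, none or still open, it means among the compounds named here.

Measured so far:
- compound 1, `COc1ccc(C2CC(c3ccc(NC(=O)c4cc(Cl)ccc4OC)cc3)=NN2c2ccccc2)cc1`: 90.2%
- compound 2, `COc1ccc(Cl)cc1C(=O)Nc1ccc(C2=NN(c3ccccc3)C(c3ccccc3[N+](=O)[O-])C2)cc1`: 84.4%

Both compounds were tested in a functional assay on the whole organism (plasma, strain albino) for inhibition, with Rattus norvegicus as the target, with stated times of 1 h and 4 h, at a dose of 50 mg/kg by the oral route; on this read-out higher numbers stand for a stronger effect at the one dose given and lower numbers for a weaker effect. Compound 1 gives 90.2% and compound 2 gives 84.4%. Going by the values given here, the one measured step is a number 5.8 percentage points lower from compound 1 to compound 2 (within the scatter), so the two numbers are within the scatter of each other and no order between them can be read. Among the compounds with values here, compound 2 stands lowest of the two numbers on paper, with compound 1 as its only neighbour, but this says nothing beyond the scatter.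

Compound 3, `COc1ccc(Cl)cc1C(=O)Nc1ccc(C2=NNC(c3ccccc3[N+](=O)[O-])C2)cc1`, is not yet measured. It differs from compound 2 by hydrogen in place of phenyl on an amine nitrogen in a ring. Within the data shown here, no measured step touches this place: the only step seen concerns the substituent on the saturated ring carbon, not the ring nitrogen, so there is no measured step on which to rest the size or direction of the change in this assay. The estimate therefore leans on compound 2 alone, with a wide range to allow for a loss. Compound 3 is expected to give about 70%, between 40% and 90%, which means an expected step of a number 14.4 percentage points lower from compound 2 to compound 3 (beyond the scatter).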

Compound 3, a percentage reported as inhibition, in the whole organism at one dose (the size of the read-out at that dose, not a potency): 84.5%
Compound 3: the middle estimate sits 14.5 percentage points below what was measured; low and high end bracket the measured number.
By their numbers in this assay, from the lowest: compounds 2, 3 and 1 (each within the scatter of the next).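

Hydrogen in place of phenyl on an amine nitrogen in a ring reads as a number 0.1 percentage points higher from compound 2 to compound 3 (within the scatter) in this assay, and this is the first reading at this position of the series. The phenyl on this ring nitrogen is therefore not required to keep the read-out at this one dose, since compound 2 and compound 3 cannot be told apart, although this is a comparison of effect size at a single dose and not of potency. Nothing available explains this outcome or ties it to any property of the phenyl or of the hydrogen.

From the compounds shown here alone, whether the same exchange holds with the 4-methoxyphenyl of compound 1 on the saturated ring carbon remains open, as does whether compound 2 and compound 3 would separate at a lower oral dose. Also open, going by these compounds, is how this ring nitrogen behaves when it carries a methyl or an acetyl group rather than phenyl or hydrogen, which would show whether any group there changes the read-out.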